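The compounds below may be only part of what the source reports. "The series", "measured", "known", "first", "only" and "open" are said of these compounds alone.

Compound 1 `Cc1n[nH]c(C(=O)O)c1Cc1cccc(C(N)=O)c1` gives 8%
Compound 2 `Cc1n[nH]c(C(=O)O)c1Cc1cccc(C(F)(F)F)c1` gives 5%
Compound 3 `Cc1n[nH]c(C(=O)O)c1Cc1cccc(C(=O)O)c1` gives 3%

Of the compounds shown here, three sharing one core have been tested in an assay on isolated protein for inhibition of 2-Hydroxyacid oxidase 2 (Homo sapiens), tested at 1 uM; on this read-out higher numbers stand for a stronger effect at the one concentration tested and lower numbers for a weaker effect. Compound 3 holds the lowest of the three numbers, yet the gap to its nearest neighbour is a number 2 percentage points lower from compound 2 to compound 3 (within the scatter) and the gap to the furthest is a number 5 percentage points lower from compound 1 to compound 3 (within the scatter); both lie within the scatter, so the three read alike.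

Compound 4 `Cc1n[nH]c(C(=O)O)c1Cc1cccc(OC(F)(F)F)c1` has not yet been measured. It differs from compound 3 in a single place: trifluoromethoxy in place of carboxy on an aromatic carbon. Going by the values given here, two measured steps bear on this change, since each also exchanged the group on that same aromatic carbon: a number 3 percentage points lower from compound 1 to compound 2 (within the scatter) and a number 2 percentage points lower from compound 2 to compound 3 (within the scatter). Neither moved the read-out beyond the scatter, and the data give no case where a change at this carbon did. Compound 4 is therefore expected to show no step beyond the scatter in this assay, an expected step of a number 2 percentage points higher from compound 3 to compound 4 (within the scatter). Compound 4 is estimated at 5%, with a range from 0% to 15%.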

Compound 4, a percentage reported as inhibition, at one concentration (the size of the read-out at that concentration, not a potency): 2%
The estimate for compound 4 lay 3 percentage points above the measured number, and the stated range covers the measured number.
By their numbers in this assay, from the lowest: compounds 4, 3, 2 and 1 (each within the scatter of the next).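

In this assay, trifluoromethoxy is a fourth group on this aromatic carbon, and the read-out again does not move beyond the scatter: a number 1 percentage points lower from compound 3 to compound 4 (within the scatter), a number 3 percentage points lower from compound 2 to compound 4 (within the scatter) and a number 6 percentage points lower from compound 1 to compound 4 (within the scatter). Exchanging carboxy, with its hydrogen-bond donor, for trifluoromethoxy, which has none, therefore changes the number no more than the earlier exchanges at this carbon did. No measurement is available to explain why the four compounds read alike.

The compounds leave open whether any other group on this carbon, such as an amine or a longer chain, would carry the number beyond the scatter, or whether a change elsewhere on the shared core would do so. The four numbers also give no ranking of the groups tested here.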